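Fluoro on the benzoyl ring of compound 1

A few compounds are considered here, and "the series" means these few. Any claim that something is new, unique, unknown or untested is made for them only; others in the source may bear on it.

Compound 1 `O=C(OC1CCC(CN2CCN(c3cc(=O)c4cc(C(F)(F)F)cc([N+](=O)[O-])c4s3)CC2)CC1)c1ccccc1` sits second highest of the three numbers in an ADME assay on cells (Hepatocyte, Mus musculus) for metabolic stability, with a stated time of 30 min (a higher number here means that more of the compound is left, a lower number that less of the compound is left), with 68.1%; compound 2 `O=c1cc(N2CCN(CC3CCC(NS(=O)(=O)c4ccccc4)CC3)CC2)sc2c([N+](=O)[O-])cc(C(F)(F)F)cc12` gives 95.3% and compound 3 `O=C(OC1CCC(CN2CCN(c3cc(=O)c4cc(C(F)(F)F)cc([N+](=O)[O-])c4s3)CC2)CC1)C1CCCCC1` gives 1.2%. The step of a number 27.2 percentage points higher from compound 1 to compound 2 (beyond the scatter) is modest, while a number 66.9 percentage points lower from compound 1 to compound 3 (beyond the scatter) and a number 94.1 percentage points lower from compound 2 to compound 3 (beyond the scatter) are large and show that the group on the saturated ring carbon governs the read-out in this series.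

Compound 4 `O=C(OC1CCC(CN2CCN(c3cc(=O)c4cc(C(F)(F)F)cc([N+](=O)[O-])c4s3)CC2)CC1)c1ccc(F)cc1` differs from compound 1 by fluoro in place of hydrogen on an aromatic carbon. Within the data shown here, none of the measured steps changes a single aromatic hydrogen; the two steps starting from compound 1 exchange whole groups, so they give only a loose guide. A fluoro entering with one heavy atom is a far smaller change than either, and no step beyond the scatter is expected in this assay. The step from compound 1 to compound 4 is therefore estimated as a number 3.9 percentage points higher from compound 1 to compound 4 (within the scatter). Compound 4 is expected to give 72%, with a range from 50% to 90%.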

Compound 4, percent of the compound remaining: 1.5%
The estimate for compound 4 lay 70.5 percentage points above the measured number; measured number outside the range, below it.
By their numbers in this assay, from the lowest: compounds 3 and 4 (each within the scatter of the next); then compound 1; then compound 2.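

In this assay the aromatic carbon of the benzoyl ring, para to a large group, proves highly sensitive: fluoro in place of hydrogen gives a number 66.6 percentage points lower from compound 1 to compound 4 (beyond the scatter), a step from one heavy atom that is as large as the exchange of phenyl for cyclohexyl. Between cyclohexyl and 4-fluorophenyl on the carbonyl carbon the record reads a number 0.3 percentage points higher from compound 3 to compound 4 (within the scatter), so these two groups cannot be told apart here, and the higher number of compound 1 rests on the unsubstituted phenyl. With ((4-fluorophenyl)carbonyl)oxy in place of (phenylsulfonyl)amino on the saturated ring carbon, the result is a number 93.8 percentage points lower from compound 2 to compound 4 (beyond the scatter), a second large gap of this kind.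

Open, on these data alone, is whether chloro or methoxy on the same aromatic carbon would follow compound 1 or compound 4. No measurement at hand bears on the reason for the fluoro step.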